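The source may report more compounds than this note shows. Statements on the series, on what has been measured and on what is new or still open speak of the compounds shown alone.

Compound 1 `C=C[C@@](C)(/C=C/c1ccc(OCc2ccccc2)cc1)CCC=C(C)C` has a benzyloxy group on an aromatic carbon. In a functional assay on SEM cells (Homo sapiens) for cytotoxicity, with a stated time of 72 h (a lower number here means that less compound is needed, a higher number that more compound is needed for the effect), compound 1 gives > 36600 nM, which is a limit of the assay and not a measured number. Compound 2 `C=C[C@@](C)(/C=C/c1ccc(O)c(/C=C/C=C/c2ccccc2)c1)CCC=C(C)C` in this assay gives > 15000 nM, also a limit. Compound 3 `CCOC(=O)/C(C)=C/c1cc(/C=C/[C@](C)(/C=C/c2ccc(OC)cc2)CCC=C(C)C)ccc1O` in this assay gives > 36600 nM, again a limit. So compound 1 stands among compounds that all failed to reach a measurable effect: the limit of > 36600 nM in this assay, at which 2 of the 3 values shown sit, and (the limit of > 15000 nM in this assay, at which 1 of the 3 values shown sits). Compound 4 `C=C[C@@](C)(/C=C/c1ccc(-c2cccc(F)c2)cc1)CCC=C(C)C` differs from compound 1 by 3-fluorophenyl in place of benzyloxy on an aromatic carbon. Going by the values given here, no step between two measured compounds is available here. The expected step in this assay is a step that the limit leaves unreadable from compound 1 to compound 4, none beyond the scatter. Compound 4 is estimated at 40000 nM, in the range 10000 nM to 150000 nM, most likely reported again as a limit.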

Compound 4, half-maximal effective concentration: > 36600 nM
Compound 4 gave a limit, no number; the forecaster's own chance of this, stated with the estimate: 75%; the middle value lies beyond the limit too.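

Compound 1 and compound 4 both give only a limit, and the step between them cannot be read: the limit of > 36600 nM in this assay, at which 3 of the 4 values shown sit. From the compounds shown here alone, what stays open is how the two compare in this assay, and at what concentration, if any, either reaches the effect.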